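Swapping the Aryl Group on the Aminopyrimidine Core

This account rests on a few compounds, and the source may have more. Where it says the series, first, only, none or still open, it means among the compounds named here.

The series centres on compound 1 `CC1(OC(=O)N2C[C@H]3COC[C@@H](C2)[C@@H]3Oc2ncnc(Nc3ccc(C#N)cc3Cl)c2F)CC1`, which was measured in a functional assay for agonist activity at Glucose-dependent insulinotropic receptor (Mus musculus), read by cAMP accumulation (a higher number here means that more compound is needed for the effect, a lower number that less compound is needed), and gives 58 nM. Going by the values given here, compound 3 `CC1(OC(=O)N2CC3COCC(C2)C3Oc2ncnc(Nc3ccc(C#N)cc3Cl)c2F)CCC1` differs from compound 1 only in the size of the carbocycle on the carbamate, and in this assay compound 3 gives 60 nM, while compound 2 `CC1(OC(=O)N2CC3COCC(C2)C3Oc2ncnc(Oc3ccccc3F)c2F)CC1`, the only member of the trio without the 2-chloro-4-cyanophenyl group, gives 75 nM. Of the three, compound 1 has the smallest number, but the gaps to compound 3 and compound 2 both fall within the usual scatter, so the three compounds cannot be told apart on these data.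

Compound 4 `CC1(OC(=O)N2C[C@H]3COC[C@@H](C2)[C@@H]3Oc2ncnc(Nc3c(F)cccc3F)c2F)CC1` has not yet been measured. It differs from compound 1 by a single exchange: 2,6-difluorophenyl in place of 2-chloro-4-cyanophenyl on a nitrogen on an aromatic ring. Among the compounds with values here, no measured pair in the set reports this particular change, so its effect is unknown here. The closest hint is compound 2, which carries a different aryl group and still gives 75 nM, suggesting that the aryl group tolerates variation without a large shift. The step from compound 1 to compound 4 is therefore expected to be small, a 1.5-fold higher number from compound 1 to compound 4 (0.17 log units; within the scatter), leaning slightly toward a higher number. Compound 4 is estimated at 85 nM, within a range of 30 nM to 250 nM.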

Compound 4, half-maximal effective concentration: 113 nM
Estimate against measurement, compound 4: 1.3-fold (0.12 log units) below; low and high end bracket the measured number.
By their numbers in this assay, from the lowest: compounds 1, 3, 2 and 4 (each within the scatter of the next).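

In this assay, going by these compounds alone, the exchange of 2-chloro-4-cyanophenyl for 2,6-difluorophenyl on a nitrogen on an aromatic ring gives the first step that can be read between two compounds differing in one place: a 1.9-fold higher number from compound 1 to compound 4 (0.29 log units; within the scatter). At this position, then, the chlorine and the nitrile can leave together and two fluorines can enter on the same shared core while the step stays within the scatter, so these two aryl groups cannot be told apart on this result. No measurement of any property of these groups is available that bears on this step.

The compounds shown leave open how the chlorine and the nitrile each count on their own, which a 2-chlorophenyl or a 4-cyanophenyl group on the same nitrogen would separate. They also leave open whether this tolerance extends beyond halogen- and nitrile-bearing phenyl rings to quite different groups, such as a pyridyl ring or a 4-methylsulfonylphenyl group.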